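This account rests on a few compounds, and the source may have more. Where it says the series, first, only, none or still open, it means among the compounds named here.

Measured compounds in a toxicity assay on THP-1 cells (Homo sapiens) for cytotoxicity, read by MTT assay, with a stated time of 72 h; on this read-out higher numbers stand for an effect only at larger amounts of compound and lower numbers for an effect already at smaller amounts:
- compound 1 `NC(=S)N/N=C/c1cn(CCCc2ccccc2)c2ccccc12`: 30000 nM
- compound 2 `Cc1ccc(/C=N/NC(N)=S)c2ccccc12`: 32000 nM
- compound 3 `CN(C)c1ccc(/C=N/N=C(/N)S)c2ccccc12`: reported only as a limit, > 200000 nM

Compound 3 returns no number; it sits at the limit of > 200000 nM in this assay, at which 1 of the 3 values shown sits. Among the two numbers, compound 2 gives the larger figure, and the nearest value is that of compound 1, the two lying within the usual scatter of each other, so no order between them is claimed.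

Compound 4 `NC(=S)N/N=C/c1ccc(OCc2ccccc2)c2ccccc12` has not yet been measured in this assay. Compared with compound 2, the change is benzyloxy in place of methyl on an aromatic carbon, the rest of the shared core unchanged. Among the compounds with values here, no step between measured compounds shows this change, so nothing measured sets its size. Starting from compound 2 at 32000 nM, the expected step is a 1.1-fold lower number from compound 2 to compound 4 (0.03 log units; within the scatter), small and not beyond the scatter in either direction. Compound 4 is accordingly expected at 30000 nM, with a range from 10000 nM to 100000 nM.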

Compound 4, half-maximal effective concentration: 27000 nM
The estimate for compound 4 lay 1.1-fold (0.05 log units) above the measured number; measured number inside the range.
By their numbers in this assay, from the lowest: compounds 4, 1 and 2 (each within the scatter of the next). At a limit, above all of these: compound 3.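

In this assay, the exchange at this aromatic carbon gives a 1.2-fold lower number from compound 2 to compound 4 (0.07 log units; within the scatter). The earlier compounds shown here offered no step at this position; this one shows that benzyloxy, with 8 heavy atoms, a six-membered aromatic ring and a hydrogen-bond acceptor, can replace methyl with the two compounds remaining within the scatter of each other. No measurement shown bears on why this exchange produces no step beyond the scatter.

Still open, as far as these compounds go, is whether any group at this aromatic carbon gives a step beyond the scatter, since a single exchange does not define what the position tolerates. A carboxylic acid or a methoxy in this place would show whether the outcome holds for a charged group or for a smaller ether.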